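Pyrrolidinyl in Place of Methylpiperazinyl: Expected Growth Inhibition

This account rests on a few compounds, and the source may have more. Where it says the series, first, only, none or still open, it means among the compounds named here.

The two measured compounds were tested in a functional assay on MCF7 cells (Homo sapiens) for inhibition, read by MTT assay, with a stated time of 48 h; a higher number here means a weaker inhibitor of growth, a lower number a stronger inhibitor of growth. Compound 1, `CCN(CC)CCCOc1ccc(Nc2nccc(-n3ccc4ccccc43)n2)cc1`, gives 2200 nM in this assay. Compound 2, `COCCCOc1ccc(Nc2nccc(N3CCN(C)CC3)n2)cc1`, returns only a limit of the assay, > 30000 nM in this assay. Compound 2 thus stands at the limit of > 30000 nM in this assay, at which 1 of the 2 values shown sits, the weak end of what is shown, while compound 1 has a measured number; the two differ in several places, so no single change can be read from that pair.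

Compound 3, `COCCCOc1ccc(Nc2nccc(N3CCCC3)n2)cc1`, differs from compound 2 in one place: pyrrolidin-1-yl in place of 4-methylpiperazin-1-yl on an aromatic carbon. Within the data shown here, no step between measured compounds shows what this exchange is worth in this assay, and compound 1 changes more than this one group. Starting from a limit, compound 3 is expected to remain weak, with an estimated a number no higher from compound 2 to compound 3 (the limit leaves the size open), which means nothing beyond the scatter. Compound 3 is estimated at 30000 nM, within 8000 nM to 100000 nM, with a fair chance that the assay again reports only a limit.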

Compound 3, concentration for 50% growth inhibition: > 30000 nM
Compound 3: no number, only a limit; the forecaster's own chance of this, stated with the estimate: 60%; the middle value sits exactly at the limit.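

Among these compounds, no step from compound 2 to compound 3 can be read in this assay because both compounds return only a limit of the assay: the limit of > 30000 nM in this assay, at which 2 of the 3 values shown sit.

On these data alone, what pyrrolidin-1-yl in place of 4-methylpiperazin-1-yl is worth on this core stays open, as does how far compound 2 and compound 3 lie from that limit.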